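The source may hold more compounds than are shown below. What is called first, only, known or untested is meant among the compounds shown, and "the series" means these compounds.

Compound 1 `O=C(/C(=C\c1ccc(I)cc1)S(=O)(=O)c1ccc(Br)cc1)c1ccc(Br)cc1` belongs to a small set of three measured compounds from this study. In a functional assay on DU-145 cells (Homo sapiens) for inhibition, read by trypan blue exclusion, with a stated time of 96 h (on this read-out higher numbers stand for weaker inhibition of growth and lower numbers for stronger inhibition of growth), compound 1 gives 1000 nM. Compound 3 `CN(C)c1ccc(/C=C(/SCc2ccc(Cl)cc2)C(=O)c2ccc(C(=O)O)cc2)cc1` gives 1000 nM in this assay, the same number at the digits reported, so the two sit together within the usual scatter and no order between them can be claimed. Compound 2 `Cc1ccc(S/C(=C/c2ccc(F)cc2C(F)(F)F)C(=O)c2ccc(Br)cc2)cc1` gives 25000 nM in this assay, a higher number than compound 1 by a margin that lies well beyond the scatter, so compound 1 and compound 3 together hold the lowest numbers of the three.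

Compound 4 `COc1ccc(/C=C(\C(=O)c2ccc(Br)cc2)S(=O)(=O)c2ccc(Br)cc2)c(OC)c1` is the next compound to be measured in this assay. It differs from compound 1 in one place: 2,4-dimethoxyphenyl in place of 4-iodophenyl on a double-bonded chain carbon bound to a double-bonded chain carbon. Going by the values given here, no measured pair in this set differs only in that place, so there is no direct precedent for the size or direction of this step.

On that basis the step from compound 1 to compound 4 is expected to be small, a 1.5-fold higher number from compound 1 to compound 4 (0.18 log units; within the scatter), most likely within the scatter or only modestly toward a higher number. Compound 4 is therefore estimated at 1500 nM in this assay, with a range from 400 nM to 6000 nM, because compound 1 gives 1000 nM and the change carries no known penalty here.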

Compound 4, concentration for 50% growth inhibition: 8000 nM
Beside the measured number, compound 4's estimate is 5.3-fold (0.73 log units) below it, outside the stated range (above it).
By their numbers in this assay, from the lowest: compounds 1 and 3 (each within the scatter of the next); then compound 4; then compound 2.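

Going by these compounds alone, this is the first step in the set that can be read at this place: in this assay, 2,4-dimethoxyphenyl in place of 4-iodophenyl on a double-bonded chain carbon bound to a double-bonded chain carbon gives an 8.0-fold higher number from compound 1 to compound 4 (0.90 log units; beyond the scatter) and so shows that the group held here is not a matter of indifference for inhibition of growth on the core of compound 1. The change is a single swap in which the iodine leaves, two oxygens enter, the group grows from 7 to 10 heavy atoms, and the count of hydrogen-bond acceptors goes from 0 to 2, and the direction of the step is toward weaker inhibition of growth. Nothing available here accounts for this loss or ties it to any one of those differences.

The compounds shown leave open whether the iodine going or the two methoxy groups coming carries the step. A single methoxy, a 4-hydroxyphenyl or a 4-bromophenyl at this place, on the same core, would begin to separate those two readings.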